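The source may report more compounds than this note shows. Statements on the series, on what has been measured and on what is new or still open speak of the compounds shown alone.

Compound 3 `COc1ccc(CN(C)C(=O)c2ccc(-c3cc(-c4cc(OC)ccc4OC)no3)s2)cc1` is one of three close analogues that share a core and differ only in the amine on the carbonyl carbon. In a functional assay on A549 cells (Homo sapiens) for cytotoxicity, read by XTT assay, with a stated time of 72 h (on this read-out higher numbers stand for weaker inhibition and lower numbers for stronger inhibition), compound 3 gives > 30000 nM, which is a limit of the assay and not a measured number. Compound 1 `COc1ccc(OC)c(-c2cc(-c3ccc(C(=O)N4CCCC4)s3)on2)c1` carries a pyrrolidin-1-yl group on that carbonyl carbon, and in this assay compound 1 gives > 30000 nM, again a limit. For the measured compounds named here, compound 2 `CCN(CC)C(=O)c1ccc(-c2cc(-c3cc(OC)ccc3OC)no2)s1` carries a diethylamino group there, and in this assay compound 2 gives 11000 nM, the only plain number among the three. The measured steps run an at least 2.7-fold lower number from compound 1 to compound 2 (0.43 log units; beyond the scatter) and an at least 2.7-fold higher number from compound 2 to compound 3 (0.43 log units; beyond the scatter), while the step that the two limits leave unreadable from compound 1 to compound 3 cannot be read because of the limit of > 30000 nM in this assay, at which 2 of the 3 values shown sit.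

Compound 4 `COc1ccc(OC)c(-c2cc(-c3ccc(C(=O)NC4CC4)s3)on2)c1` introduces a new amine: cyclopropylamino in place of (4-methoxybenzyl)(methyl)amino on a carbonyl carbon. The steps on this carbonyl carbon show that the amine matters, but only the diethylamino group of compound 2 gave a readable number, and two of the three amines sit at the limit. A cyclopropylamino group resembles neither of them closely, so the expected step from compound 3 to compound 4 is estimated as an at least 1.2-fold lower number from compound 3 to compound 4 (0.07 log units; that floor lies within the scatter), with a real chance that the assay again reports only a limit. For compound 4 in this assay the estimate is 25000 nM, expected to lie between 8000 nM and 80000 nM.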

Compound 4, half-maximal inhibitory concentration: > 30000 nM
Compound 4 gave a limit, no number (the forecaster's own chance of this, stated with the estimate: 50%); at least 1.2-fold (0.07 log units) between middle value and limit.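

For the compounds shown here, compound 4 is the first here to carry a hydrogen-bond donor on this carbonyl carbon, and in this assay compound 4 gives > 30000 nM, which is a limit of the assay and not a number. Cyclopropylamino in place of diethylamino gives an at least 2.7-fold higher number from compound 2 to compound 4 (0.43 log units; beyond the scatter), so compound 2 remains the only one of the four with a plain number, and neither the small cyclopropylamino group of compound 4 nor the larger (4-methoxybenzyl)(methyl)amino group of compound 3 brings a readable value. The steps from compound 1 and from compound 3 to compound 4 cannot be read, because both ends of each step are limits: the limit of > 30000 nM in this assay, at which 3 of the 4 values shown sit.

From the compounds shown here alone, the order among compound 1, compound 3 and compound 4 therefore stays open, since none of the three has a number to set against the others. Also open, going by these compounds, is whether the readable value of compound 2 is particular to diethylamino, or whether an ethylamino group, which keeps one ethyl chain together with the amide hydrogen, or a dipropylamino group would also give a number.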